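The compounds below may be only part of what the source reports. "The series", "measured", "known", "first", "only" and "open" are said of these compounds alone.

In a functional assay on VCaP cells (Homo sapiens) for antiproliferative activity, read by CCK-8 assay, with a stated time of 6 days (on this read-out lower numbers stand for stronger inhibition and higher numbers for weaker inhibition), compound 1 (`C[C@@H](Cn1ccc(-c2ccc(C#N)c(Cl)c2)n1)NC(=O)c1ccccc1`) gives "not determined" (no result reported), while compound 2 (`C[C@@H](Cn1ccc(-c2ccc(C#N)c(Cl)c2)n1)NC(=O)C1CC(=O)C1`) gives 22500 nM. Compound 3 (`CC(=O)c1ccc(S(=O)(=O)N[C@@H](C)Cn2ccc(-c3ccc(C#N)c(Cl)c3)n2)cc1`) gives 3950 nM, the lower of the two numbers available and a gap from compound 2 that lies beyond the usual scatter. Compound 4 (`C[C@@H](Cn1ccc(-c2ccc(C#N)c(Cl)c2)n1)NS(=O)(=O)c1cccnc1`) carries pyridin-3-yl in place of 4-acetylphenyl on a sulfonyl sulfur. Among the measured compounds shown here, no measured pair isolates this change, so the expectation rests on little. For the measured compounds named here, compound 3 at 3950 nM is the only sulfonyl compound with a number, and compound 2 at 22500 nM shows how high numbers run here. A moderate move to weaker inhibition in this assay is expected, a 1.8-fold higher number from compound 3 to compound 4 (0.25 log units; within the scatter). For compound 4 the estimated value is 7000 nM, with an expected range of 2500 nM to 20000 nM.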

Compound 4, half-maximal inhibitory concentration: 2450 nM
Estimate against measurement, compound 4: 2.9-fold (0.46 log units) above; measured number outside the range, below it.
By their numbers in this assay, from the lowest: compounds 4 and 3 (each within the scatter of the next); then compound 2.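

In this assay the change on the sulfonyl sulfur gives a 1.6-fold lower number from compound 3 to compound 4 (0.21 log units; within the scatter), so pyridin-3-yl and the larger 4-acetylphenyl cannot be told apart at this position. The change on the amine nitrogen gives a 9.2-fold lower number from compound 2 to compound 4 (0.96 log units; beyond the scatter), which shows a (pyridin-3-yl)sulfonyl group set clearly apart from (3-oxocyclobutyl)carbonyl. Nothing available accounts for either step. The compounds shown leave open how a small methyl group or a 4-aminophenyl group on the sulfonyl sulfur would compare with these two aromatic rings.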